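Swapping the Pyrrole Ring for a Thiophene Ring

The source may report more compounds than this note shows. Statements on the series, on what has been measured and on what is new or still open speak of the compounds shown alone.

Compound 1 `CC1=CC[C@H](C(C)(C)NC(=S)N/N=C/c2cccc(Cl)c2)CC1`: 8000 nM
Compound 2 `CC1=CC[C@H](C(C)(C)NC(=S)N/N=C/c2ccc[nH]2)CC1`: 3900 nM

Both compounds were tested in a functional assay on MCF7 cells (Homo sapiens) for inhibition, read by sulforhodamine B assay, with a stated time of 48 h; a lower number here means a stronger inhibitor of growth, a higher number a weaker inhibitor of growth. On the two numbers available, compound 2 gives the lowest; its nearest neighbour is compound 1, and the step of a 2.1-fold lower number from compound 1 to compound 2 (0.31 log units; beyond the scatter) lies beyond the usual scatter of this kind of measurement.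

Compound 3 `CC1=CC[C@H](C(C)(C)NC(=S)N/N=C/c2cccs2)CC1` has not yet been measured. It differs from compound 2 in one place only: thiophen-2-yl in place of 1H-pyrrol-2-yl on a carbon with a double bond to nitrogen. For the measured compounds named here, no measured step covers this exact exchange. Going by the values given here, the single step known, a 2.1-fold lower number from compound 1 to compound 2 (0.31 log units; beyond the scatter), concerns a different pair of groups at the same place, and it shows that exchanging the ring there moved the number only modestly. On that basis a small step is expected here as well, with a somewhat higher number for compound 3 than for compound 2 seeming a little more likely than a lower one, so that compound 3 would sit between compound 2 and compound 1. Compound 3 is therefore estimated at 5000 nM, with a range from 2000 nM to 12000 nM. This amounts to an expected step of a 1.3-fold higher number from compound 2 to compound 3 (0.11 log units; within the scatter) in this assay.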

Compound 3, concentration for 50% growth inhibition: 4800 nM
The estimate for compound 3 lay 1.0-fold (0.02 log units) above the measured number; the measured number falls inside the stated range.
By their numbers in this assay, from the lowest: compounds 2, 3 and 1 (each within the scatter of the next, the first and the last beyond it).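

In this assay, thiophen-2-yl in place of 1H-pyrrol-2-yl gives a 1.2-fold higher number from compound 2 to compound 3 (0.09 log units; within the scatter) and so, within these two compounds, removing the 1 hydrogen-bond donor of the leaving ring and exchanging its nitrogen for sulfur brings no change that can be told from the scatter. Thiophen-2-yl in place of 3-chlorophenyl gives a 1.7-fold lower number from compound 1 to compound 3 (0.22 log units; within the scatter) while 1H-pyrrol-2-yl in the same exchange gives a 2.1-fold lower number from compound 1 to compound 2 (0.31 log units; beyond the scatter) and thus only the pyrrole step clears the scatter, and only modestly, so all three aromatic rings on this carbon with a double bond to nitrogen give numbers in a narrow band. No measurement of any property of these groups accompanies the numbers, so nothing can be said about what lies behind them.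

From the compounds shown here alone, all three groups at this place are aromatic rings, so it remains open whether an amine, a carboxylic acid or a longer alkyl chain there would move the number further than these rings do. Also open, going by these compounds, is what an unsubstituted phenyl ring would give, which would separate the part played by the chlorine from that of the ring carrying it.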